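This account rests on a few compounds, and the source may have more. Where it says the series, first, only, none or still open, it means among the compounds named here.

Of the compounds shown here, three that share one core have so far been tested in a functional assay on MRC5 cells (Homo sapiens) for cytotoxicity, read by MTT assay, with a stated time of 48 h; on this read-out lower numbers stand for stronger inhibition and higher numbers for weaker inhibition. Compound 1 `O=C(O[C@H]1C[C@H](n2cc(F)c(=O)[nH]c2=O)O[C@@H]1COP(=O)(O)Oc1ccccc1)c1ccccc1` gives 1270 nM in this assay. Compound 2 `O=C(O[C@H]1C[C@H](n2cc(F)c(=O)[nH]c2=O)O[C@@H]1COP(=O)(O)Oc1cccnc1)c1ccccc1` gives 15600 nM, and compound 3 `O=c1[nH]c(=O)n([C@H]2C[C@H](O)[C@@H](COP(=O)(O)Oc3ccccc3)O2)cc1F` gives 36700 nM. Compound 3 therefore stands at the high end of the three, the weakest inhibitor of cell growth among them; its number rose a 29-fold higher number from compound 1 to compound 3 (1.46 log units; beyond the scatter) through hydrogen in place of benzoyl on an oxygen on a saturated carbon.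

Compound 4 `O=c1[nH]c(=O)n([C@H]2C[C@H](O)[C@@H](COP(=O)(O)Oc3cccnc3)O2)cc1F` has not yet been measured. It differs from compound 3 in one place: pyridin-3-yl in place of phenyl on an oxygen

Within the data shown here, one measured step bears directly on this. The same swap, pyridin-3-yl in place of phenyl on an oxygen, has been made once before, and the number rose a 12-fold higher number from compound 1 to compound 2 (1.09 log units; beyond the scatter). If the swap acts alike on compound 3, a rise of similar size in this assay is expected, toward weaker inhibition. Compound 4 is thus estimated at 300000 nM in this assay. The expected range for compound 4 runs from 100000 nM to 1000000 nM. This expectation amounts to a step of an 8.2-fold higher number from compound 3 to compound 4 (0.91 log units; beyond the scatter).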

Compound 4, half-maximal inhibitory concentration: 8500 nM
Estimate against measurement, compound 4: 35-fold (1.55 log units) above, outside the stated range (below it).
By their numbers in this assay, from the lowest: compound 1; then compounds 4 and 2 (each within the scatter of the next); then compound 3.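

In this assay, pyridin-3-yl in place of phenyl on the oxygen bonded to phosphorus now gives a 4.3-fold lower number from compound 3 to compound 4 (0.64 log units; beyond the scatter), so this swap has no fixed direction across the two cores. Its outcome depends on whether benzoyl or hydrogen sits on the oxygen on a saturated carbon: the same change on two cores in this assay, a 12-fold higher number (1.09 log units; beyond the scatter) from compound 1 to compound 2 and a 4.3-fold lower number (0.64 log units; beyond the scatter) from compound 3 to compound 4, 53-fold (1.72 log units) apart, beyond the scatter of two such steps The benzoyl change depends on the other site in turn, as hydrogen in place of benzoyl gives only a 1.8-fold lower number from compound 2 to compound 4 (0.26 log units; within the scatter) when pyridin-3-yl is present, a far smaller step than with phenyl: the same change on two cores in this assay, a 29-fold higher number (1.46 log units; beyond the scatter) from compound 1 to compound 3 and a 1.8-fold lower number (0.26 log units; within the scatter) from compound 2 to compound 4, 53-fold (1.72 log units) apart, beyond the scatter of two such steps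

Among these compounds, these four compounds pair only two groups at each site, so they cannot explain why the two changes depend on each other. From the compounds shown here alone, it remains open whether acetyl in place of benzoyl, or naphthyl in place of phenyl, would show the same reversal.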